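Isopropyl for cyclobutyl in a series near the limit

The source may hold more compounds than are shown below. What is called first, only, known or untested is meant among the compounds shown, and "the series" means these compounds.

Compound 3 `O=C(C1CC2(CCN(C3CCOCC3)CC2)C1)N1CCN(C2CCC2)CC1` has no exact value in a physicochemical assay for solubility, measured as thermodynamic solubility, at pH 7.4; a higher number here means a more soluble compound, a lower number a less soluble compound: compound 3 gives > 500000 nM, which is a limit and not a number. Compound 1 `O=C(C1CC12CCN(C1CCOCC1)CC2)N1CCN(C2CCCC2)CC1` likewise gives only a limit, > 500000 nM. Compound 2 `O=C(C1CC12CCC(C1CCCCC1)CC2)N1CCN(C2CCC2)CC1` gives a numerical value, 1000 nM.

Compound 4 `CC(C)N1CCN(C(=O)C2CC3(CCN(C4CCOCC4)CC3)C2)CC1` carries isopropyl in place of cyclobutyl on an amine nitrogen in a ring. Going by the values given here, no measured pair isolates this change, and no step beyond the scatter is expected in this assay. This expectation rests on the limit of compound 3, > 500000 nM, so a further limit is the likely report. The estimated value for compound 4 is 500000 nM, with an expected range of 200000 nM to 1000000 nM.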

Compound 4, solubility: > 500000 nM
Compound 4: only a limit was reported; the forecaster's own chance of this, stated with the estimate: 80%; the middle value lies on the limit itself.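

Compound 3 and compound 4 both report only a limit, so no step can be read between them: the limit of > 500000 nM in this assay, at which 3 of the 4 values shown sit.

The compounds shown leave open whether isopropyl in place of cyclobutyl on an amine nitrogen in a ring shifts the read-out at all.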